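The source may report more compounds than this note shows. Statements on the series, on what has been measured and on what is new or still open speak of the compounds shown alone.

In a functional assay on MCF7 cells (Homo sapiens) for antiproliferative activity, read by CCK-8 assay, with a stated time of 48 h (a lower number here means a stronger inhibitor, a higher number a weaker inhibitor), compound 1 `O=C(/C=C/CNCCOc1ccc(Oc2c(-c3ccc(F)cc3)sc3cc(O)ccc23)cc1)N1CCCCC1` gives 16400 nM, and compound 2 `O=C(/C=C/CN1CC(Oc2ccc(Oc3c(-c4ccc(F)cc4)sc4cc(O)ccc34)cc2)C1)N1CCCC1` gives 8450 nM, the lower of the two numbers, though compound 1 lies within the scatter of it. Compound 3 `CNC(=O)/C=C/CN1CC(Oc2ccc(Oc3c(-c4ccc(F)cc4)sc4cc(O)ccc34)cc2)C1` differs from compound 2 in a single place: methylamino in place of pyrrolidin-1-yl on a carbonyl carbon. Going by the values given here, no pair of measured compounds shows what this change does, so no shift beyond the scatter is expected in either direction. Compound 3 is therefore expected to give about 9000 nM, within 4000 nM to 20000 nM. The expected step of a 1.1-fold higher number from compound 2 to compound 3 (0.03 log units; within the scatter) is thus small.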

Compound 3, half-maximal inhibitory concentration: > 25000 nM
Compound 3: only a limit was reported; the forecaster's own chance of this, stated with the estimate: 5%; at least 2.7-fold (0.44 log units) between middle value and limit.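

Compound 3 is reported only as a limit of the assay: the limit of > 25000 nM in this assay, at which 1 of the 3 values shown sits. Even so, methylamino in place of pyrrolidin-1-yl on a carbonyl carbon brings, in this assay, an at least 2.9-fold higher number from compound 2 to compound 3 (0.47 log units; beyond the scatter), so the group at this place is not interchangeable, and the full size of the step stays unknown. Going by these compounds, whether the step goes with the loss of the ring, the fewer heavy atoms or the amide hydrogen stays open, as the two compounds change all three together. Dimethylamino or morpholin-4-yl on this carbonyl carbon would begin to separate them.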